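A few compounds are considered here, and "the series" means these few. Any claim that something is new, unique, unknown or untested is made for them only; others in the source may bear on it.

Compound 1 `COc1ccc(C(c2c[nH]c3ccc(Br)cc23)c2c[nH]c3ccc(Br)cc23)c(OC)c1` gives 77500 nM
Compound 2 `CN(C)c1ccc(C(c2c[nH]c3ccc(Br)cc23)c2c[nH]c3ccc(Br)cc23)cc1` gives 24900 nM

In a functional assay on MCF7 cells (Homo sapiens) for inhibition, read by MTT assay, with a stated time of 48 h (on this read-out lower numbers stand for stronger inhibition and higher numbers for weaker inhibition), compound 2 holds the lower of the two numbers, so it is the stronger inhibitor of this pair. Compound 3 `Clc1ccc(C(c2c[nH]c3ccc(Br)cc23)c2c[nH]c3ccc(Br)cc23)cc1` differs from compound 2 in one place (chloro in place of dimethylamino on an aromatic carbon): chloro in place of dimethylamino on an aromatic carbon. For the measured compounds named here, only one measured step bears on this change: a 3.1-fold lower number from compound 1 to compound 2 (0.49 log units; beyond the scatter) when 4-(dimethylamino)phenyl took the place of 2,4-dimethoxyphenyl. Going by the values given here, that step is modest and touches the same part of the molecule, but no measured compound carries chloro, so it offers only a rough guide. A step of similar modest size at most is therefore expected, leaning towards a higher number. The estimated change is a 1.4-fold higher number from compound 2 to compound 3 (0.15 log units; within the scatter) and no large shift is expected. The estimate for compound 3 is 35000 nM (expected range 12000 nM to 90000 nM).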

Compound 3, half-maximal inhibitory concentration: 3500 nM
For compound 3 the middle estimate is 10-fold (1.00 log units) above the measured one; measured number below the stated range.
By their numbers in this assay, from the lowest: compound 3; then compound 2; then compound 1.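

In this assay, the group on the aromatic carbon para to a large group matters more than the first pair suggested: chloro in place of dimethylamino gives a 7.1-fold lower number from compound 2 to compound 3 (0.85 log units; beyond the scatter). Replacing 2,4-dimethoxyphenyl with 4-chlorophenyl gives a 22-fold lower number from compound 1 to compound 3 (1.35 log units; beyond the scatter), the largest step among these compounds, and compound 3 is the strongest inhibitor of the three. Nothing available here explains why this change has an effect of this size.

From the compounds shown here alone, what remains open is whether chloro itself is needed, or whether fluoro, methyl or a carboxylic acid at the same place would give a similar number. Going by these compounds, it is also open whether chloro would have the same effect at another place on this ring, or with the rest of the shared core changed.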